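Notes on three measured analogues and a fourth to come

This account rests on a few compounds, and the source may have more. Where it says the series, first, only, none or still open, it means among the compounds named here.

Measured so far:
Compound 1 `Cc1cc(O)c(C2=NN(c3ccc(S(N)(=O)=O)cc3)C(c3ccccc3O)C2)cc1Cl`: in a functional assay on UACC-62 cells (Homo sapiens) for antiproliferative activity, with a stated time of 48 h (a higher number here means a weaker inhibitor of growth, a lower number a stronger inhibitor of growth), compound 1 gives 3540 nM.
Compound 2 `Cc1cc(O)c(C2=NN(c3ccc(S(N)(=O)=O)cc3)C(c3ccccc3Cl)C2)cc1Cl`: in this assay compound 2 gives 3710 nM.
Compound 3 `Cc1cc(O)c(C2=NN(c3ccc(S(N)(=O)=O)cc3)C(/C=C/c3ccccc3)C2)cc1Cl`: in this assay compound 3 gives 2890 nM.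

Compound 3 carries the lowest of the three numbers, but the two steps that lead to it, a 1.2-fold lower number from compound 1 to compound 3 (0.09 log units; within the scatter) and a 1.3-fold lower number from compound 2 to compound 3 (0.11 log units; within the scatter), both lie inside the scatter, so no ordering among the three can be claimed.

Compound 4 `COc1ccc(C2CC(c3cc(Cl)c(C)cc3O)=NN2c2ccc(S(N)(=O)=O)cc2)cc1OC` differs from compound 3 in one place: 3,4-dimethoxyphenyl in place of 2-phenylethenyl on a saturated ring carbon. Two measured steps alter the same saturated ring carbon and therefore bear on this change: a 1.2-fold lower number from compound 1 to compound 3 (0.09 log units; within the scatter) and a 1.3-fold lower number from compound 2 to compound 3 (0.11 log units; within the scatter). Neither exchange of the group at that carbon moved the number beyond the scatter. The remaining step, a 1.0-fold higher number from compound 1 to compound 2 (0.02 log units; within the scatter), changed only a substituent on the attached aromatic ring and was likewise flat. Nothing in the data shows that the group at this carbon shifts the read-out.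

For compound 4 the expected step is therefore a 1.1-fold higher number from compound 3 to compound 4 (0.06 log units; within the scatter), none beyond the scatter. Compound 4 is estimated at 3300 nM, with a range from 1500 nM to 7500 nM.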

Compound 4, concentration for 50% growth inhibition: 3130 nM
For compound 4 the middle estimate is 1.1-fold (0.02 log units) above the measured one, and the stated range covers the measured number.
By their numbers in this assay, from the lowest: compounds 3, 4, 1 and 2 (each within the scatter of the next).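

At the saturated ring carbon of the shared core, 3,4-dimethoxyphenyl gives steps within the scatter against all three earlier groups in this assay (a 1.1-fold higher number from compound 3 to compound 4 (0.03 log units; within the scatter); a 1.2-fold lower number from compound 2 to compound 4 (0.07 log units; within the scatter); a 1.1-fold lower number from compound 1 to compound 4 (0.05 log units; within the scatter)). The earlier compounds shown here covered only 2-hydroxyphenyl, 2-chlorophenyl and 2-phenylethenyl, whereas this group has 10 heavy atoms, including 2 oxygen, and 2 hydrogen-bond acceptors, so the flat picture at this carbon now extends to a larger group with two methoxy substituents on its ring. No measurement at hand accounts for this lack of separation among the four compounds.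

Whether an aliphatic amine, a carboxylic acid or a longer alkyl chain at this carbon would give a step beyond the scatter remains open, since all four groups shown carry a six-membered aromatic ring of carbon only. The 5-chloro-2-hydroxy-4-methylphenyl and 4-sulfamoylphenyl groups are the same in all four compounds, so the compounds shown also leave open what a change at either of those groups would do in this assay.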